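The compounds below may be only part of what the source reports. "The series", "measured", "known", "first", "only" and "open" are said of these compounds alone.

Compound 3, `CCc1cc(C(C)=O)c(O)cc1OCCCC(C)(C)C(=O)O`, stands with the second highest number of the three measured in an assay on isolated protein for binding affinity to leukotriene B4 receptor (Homo sapiens), tested at 0.1 uM (a lower number here means less inhibition, a higher number more inhibition at the concentration tested (going by the name of the read-out)), although both neighbours lie within the usual scatter of it: compound 1, `CCc1cc(C(C)=O)c(O)cc1OCCCC(C)(C)C#N`, gives 13%, compound 2, `CCc1cc(C(C)=O)c(O)cc1OCCCCCCC(C)(C)C#N`, gives 11%, and compound 3 gives 12%. The three differ only in the chain and its end group, and every step among them stays within the scatter: a number 2 percentage points lower from compound 1 to compound 2 (within the scatter), a number 1 percentage points lower from compound 1 to compound 3 (within the scatter) and a number 1 percentage points higher from compound 2 to compound 3 (within the scatter).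

Compound 4, `CCc1cc(C(C)=O)c(O)cc1OCCCC(C)(C)C(N)=O`, keeps the chain of compound 3 and differs only at its end: amino in place of hydroxy on a carbonyl carbon. The measured step that bears most directly on this change is a number 1 percentage points lower from compound 1 to compound 3 (within the scatter), as it too exchanges the group on the saturated chain carbon bound to three saturated chain carbons, and it stayed within the scatter. The steps that alter the chain length, a number 2 percentage points lower from compound 1 to compound 2 (within the scatter) and a number 1 percentage points higher from compound 2 to compound 3 (within the scatter), were likewise within the scatter. The estimated step from compound 3 to compound 4 is therefore no change at the digits printed from compound 3 to compound 4 (within the scatter), nothing beyond the scatter, expected because a number 1 percentage points lower from compound 1 to compound 3 (within the scatter) already showed the end group leaving the number essentially unmoved in this assay. Compound 4 is thus expected to give about 12% in this assay, within a range from 3% to 22%.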

Compound 4, a percentage reported as inhibition, at one concentration (the size of the read-out at that concentration, not a potency): 16%
Compound 4: the middle estimate sits 4 percentage points below what was measured, within the range that was stated.
By their numbers in this assay, from the lowest: compounds 2, 3, 1 and 4 (each within the scatter of the next).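

Exchanging hydroxy for amino on the carbonyl carbon gives, in this assay, a number 4 percentage points higher from compound 3 to compound 4 (within the scatter), so at this position the carboxy and carbamoyl ends cannot be told apart. The carbamoyl end also stays within the scatter of both nitrile compounds, with a number 3 percentage points higher from compound 1 to compound 4 (within the scatter) on the same chain and a number 5 percentage points higher from compound 2 to compound 4 (within the scatter) against the compound with the longer chain, so all four compounds now form a single group in which neither the end group nor the chain length shows a resolved effect. Nothing available explains the numbers or bears on the result of this exchange.

Going by these compounds, what remains open is whether a different end group, such as a primary amine or a methyl ester, or a longer chain carrying the carbamoyl end, would move the number beyond the scatter. All four numbers also come from a single tested concentration, so they give no potency, and any real differences among these compounds could only be sought with further concentrations or repeated measurements.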